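A few compounds are considered here, and "the series" means these few. Any claim that something is new, unique, unknown or untested is made for them only; others in the source may bear on it.

Compound 3, `CC(C(=O)N1CCC(F)(F)CC1)N1CCN(S(=O)(=O)c2ccc(C(C)(C)C)cc2)CC1`, sits at the edge of what the assay can report: in an ADME assay on HepG2 cells (Homo sapiens) for inhibition, with a stated time of 48 h (a higher number here means that more compound is needed for the effect, a lower number that less compound is needed), compound 3 gives > 40000 nM, which is a limit of the assay and not a number. Compound 1, `C[C@H](C(=O)N1CCCCC1)N1CCN(S(=O)(=O)c2ccc(C(C)(C)C)cc2)CC1`, gives > 40000 nM, again a limit. Compound 2, `C[C@@H](C(=O)N1CCC(F)(F)CC1)N1CCN(S(=O)(=O)c2ccc(C(C)(C)C)cc2)CC1`, gives > 40000 nM, also a limit. The step that the two limits leave unreadable from compound 2 to compound 3 therefore cannot be read, because the limit of > 40000 nM in this assay, at which 3 of the 3 values shown sit, leaves no number to compare. Compound 4, `CC(C(=O)N(C)Cc1ccccc1)N1CCN(S(=O)(=O)c2ccc(C(C)(C)C)cc2)CC1`, brings (benzyl(methyl)amino in place of 4,4-difluoropiperidin-1-yl on a carbonyl carbon). Within the data shown here, no measured step touches this change, and every value shown is a limit, so no direction can be taken from the data. Compound 4 is expected to give 40000 nM, between 10000 nM and 120000 nM. The estimated step of a number no higher from compound 3 to compound 4 (the limit leaves the size open) is expected to be none beyond the scatter.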

Compound 4, half-maximal effective concentration: > 40000 nM
Compound 4: only a limit was reported; the forecaster's own chance of this, stated with the estimate: 75%; the middle value lies on the limit itself.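

No step can be read from compound 3 to compound 4, since both sit at the same assay limit: the limit of > 40000 nM in this assay, at which 4 of the 4 values shown sit.

From the compounds shown here alone, whether benzyl(methyl)amino and 4,4-difluoropiperidin-1-yl differ at all in this assay stays open.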